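The compounds below may be only part of what the source reports. "The series", "measured", "known", "first", "only" and "open" are said of these compounds alone.

Compound 1 `COc1cc(CCc2ccccc2)cc(OC)c1O`: 10900 nM
Compound 2 `COc1cc(CCc2ccccc2Cl)cc(OC)c1O`: 2130 nM

In a functional assay on A549 cells (Homo sapiens) for antiproliferative activity, read by MTT assay, with a stated time of 72 h (on this read-out lower numbers stand for stronger inhibition and higher numbers for weaker inhibition), compound 2 has the lower of the two numbers, at 2130 nM. Compound 3 `COc1cc(CCc2ccccc2F)cc(OC)c1O` differs from it by fluoro in place of chloro on an aromatic carbon, ortho to a large group. Among the compounds with values here, only one measured step bears on this, chloro in place of hydrogen on an aromatic carbon, which gave a 5.1-fold lower number from compound 1 to compound 2 (0.71 log units; beyond the scatter). Within the data shown here, no fluoro compound has been measured yet, so a partial return toward compound 1 in this assay is expected, smaller than that step. The estimated change is a 1.9-fold higher number from compound 2 to compound 3 (0.27 log units; within the scatter). Compound 3 is expected at 4000 nM, within an estimated range of 1600 nM to 10000 nM.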

Compound 3, half-maximal inhibitory concentration: > 25000 nM
Compound 3: a limit, no number (the forecaster's own chance of this, stated with the estimate: 3%); middle value at least 6.2-fold (0.79 log units) from the limit.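

In this assay, compound 3 gives only a limit of the assay, > 25000 nM, and not an exact number. Exchanging one halogen for the other gives an at least 11-fold higher number from compound 2 to compound 3 (1.06 log units; beyond the scatter), and fluoro in place of hydrogen gives an at least 2.2-fold higher number from compound 1 to compound 3 (0.36 log units; beyond the scatter), so at this position chloro and fluoro move the number in opposite directions. A single-atom change here can therefore matter greatly.

The compounds shown leave open why the two halogens differ and how weak compound 3 really is. As far as these compounds go, whether a bromo or a methyl group here would behave like chloro also remains open.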